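A few compounds are considered here, and "the series" means these few. Any claim that something is new, unique, unknown or untested is made for them only; others in the source may bear on it.

Compound 1 `O=C(O)CCC/C=C1\CC2C[C@@H](O)[C@H](/C=C/[C@@H](O)C3COc4ccccc4O3)C2C1` and compound 2 `O=C(O)CCC/C=C1\CC2C[C@@H](O)[C@H](/C=C/[C@@H](O)C3Cc4ccccc4C3)C2C1` share one core and differ in a single place. In a functional assay on the whole organism (stomach) for inhibition, with Rattus norvegicus as the target (on this read-out lower numbers stand for an effect already at smaller amounts and higher numbers for an effect only at larger amounts of compound), compound 1 gives 0.0045 mg/kg, while compound 2 gives 0.0562 mg/kg. The change between them is 2,3-dihydro-1H-inden-2-yl in place of 2,3-dihydro-1,4-benzodioxin-2-yl on a saturated chain carbon bound to a double-bonded chain carbon and an oxygen on a saturated carbon and it made a step of a 12-fold higher number from compound 1 to compound 2 (1.10 log units; beyond the scatter).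

Compound 3 `O=C(O)COCCC1=C[C@H]2C[C@@H](O)[C@H](/C=C/[C@@H](O)C3COc4ccccc4O3)C2C1` has a different core; the difference between the two cores is not broken down here. In this assay compound 3 gives 0.0085 mg/kg, and compound 3 and compound 1 lie within the usual scatter of each other, so no order between them can be read from these two numbers alone.

Compound 4 `O=C(O)COCCC1=C[C@H]2C[C@@H](O)[C@H](/C=C/[C@@H](O)C3Cc4ccccc4C3)C2C1` has not yet been measured. Among the compounds with values here, it arises from compound 3 by 2,3-dihydro-1H-inden-2-yl in place of 2,3-dihydro-1,4-benzodioxin-2-yl on a saturated chain carbon bound to a double-bonded chain carbon and an oxygen on a saturated carbon, which is the same change as the one from compound 1 to compound 2, made at the same kind of place. For compound 4 in this assay a step of about a 12-fold higher number from compound 3 to compound 4 (1.07 log units; beyond the scatter) is expected, set beside the earlier one, because that same change gave a 12-fold higher number from compound 1 to compound 2 (1.10 log units; beyond the scatter) on the other core and the starting values of the two cores are close. The estimate for compound 4 is 0.1 mg/kg, with a likely range from 0.03 mg/kg to 0.35 mg/kg.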

Compound 4, dose for half-maximal effect: 0.0274 mg/kg
Beside the measured number, compound 4's estimate is 3.6-fold (0.56 log units) above it; the measured number lies below the stated range.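

In this assay the change from 2,3-dihydro-1,4-benzodioxin-2-yl to 2,3-dihydro-1H-inden-2-yl again goes the same way, giving a 3.2-fold higher number from compound 3 to compound 4 (0.51 log units; beyond the scatter) and showing that the direction of the change held on the second core. The size of the step did not carry over, and the gap between the two steps is larger than repeated measurements would explain: the same change on two cores in this assay, a 12-fold higher number (1.10 log units; beyond the scatter) from compound 1 to compound 2 and a 3.2-fold higher number (0.51 log units; beyond the scatter) from compound 3 to compound 4, 3.9-fold (0.59 log units) apart, beyond the scatter of two such steps. With a single pair on each core, this supports the direction only for these two cores; it does not show how large the step would be on any other core, and it does not explain why the two sizes differ.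

The compounds shown leave open whether a similar gap between the cores would appear with another group at the same place, such as a plain phenyl ring or a longer carbon chain. On these data alone, it also remains open how the two cores would compare with an amide in place of the carboxylic acid.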